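The source may hold more compounds than are shown below. What is called first, only, known or untested is meant among the compounds shown, and "the series" means these compounds.

Three measured compounds share one core and differ only in the group carried on an aromatic carbon. Compound 1 `Cc1cc(-c2cnc(NCc3c(F)ccc4c3CCO4)c3cn[nH]c(=O)c23)n(C)n1` bears a 1,3-dimethyl-1H-pyrazol-5-yl group, compound 2 `CNC(=O)c1ccc(-c2cnc(NCc3c(F)ccc4c3CCO4)c3cn[nH]c(=O)c23)c(C)n1` a 2-methyl-6-(methylcarbamoyl)pyridin-3-yl group, and compound 3 `O=C1CCCN1c1cnc(NCc2c(F)ccc3c2CCO3)c2cn[nH]c(=O)c12` a 2-oxopyrrolidin-1-yl group. In an ADME assay on microsomes from liver (Homo sapiens) for metabolic stability, read by LC-MS, using NADPH, with stated times of 5 min and 30 min, tested at 1 uM (on this read-out lower numbers stand for slow clearance and higher numbers for fast clearance), compound 1 gives 24 mL.min-1.g-1. In this assay compound 2 gives 23 mL.min-1.g-1, and compound 3 gives 23 mL.min-1.g-1. Compound 3 stands level with compound 2 at the digits shown, the two together the lowest of the three numbers, and every step among them is flat: a 1.0-fold lower number from compound 1 to compound 2 (0.02 log units; within the scatter), a 1.0-fold lower number from compound 1 to compound 3 (0.02 log units; within the scatter), and no change at the digits printed from compound 2 to compound 3 (within the scatter).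

Compound 4 `Cc1nc(CN(C)C)ccc1-c1cnc(NCc2c(F)ccc3c2CCO3)c2cn[nH]c(=O)c12` has not been measured. Its change from compound 3 is 6-((dimethylamino)methyl)-2-methylpyridin-3-yl in place of 2-oxopyrrolidin-1-yl on an aromatic carbon. Within the data shown here, the step that bears most on it is the one from compound 2 to compound 3, in which a pyridin-3-yl group of related shape gave way to the same pyrrolidinone without any movement in the number, and the step from compound 1 to compound 3 was likewise flat. With three different groups at this carbon all giving the same reading, no step beyond the scatter is expected; compound 4 is expected at 25 mL.min-1.g-1, within 12 mL.min-1.g-1 to 50 mL.min-1.g-1, meaning an expected step of a 1.1-fold higher number from compound 3 to compound 4 (0.04 log units; within the scatter).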

Compound 4, intrinsic clearance in microsomes: 13 mL.min-1.g-1
Compound 4: the middle estimate sits 1.9-fold (0.28 log units) above what was measured, within the range that was stated.
By their numbers in this assay, from the lowest: compounds 4, 2, 3 and 1 (each within the scatter of the next).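

In this assay this aromatic carbon now carries a fourth group with the reading still inside the scatter: replacing the 2-oxopyrrolidin-1-yl group with the larger 6-((dimethylamino)methyl)-2-methylpyridin-3-yl group gives a 1.8-fold lower number from compound 3 to compound 4 (0.25 log units; within the scatter) and replacing the 1,3-dimethyl-1H-pyrazol-5-yl group gives a 1.8-fold lower number from compound 1 to compound 4 (0.27 log units; within the scatter). The closest pair adds something new, since only the end of the pyridine substituent differs, and (dimethylamino)methyl in place of methylcarbamoyl gives a 1.8-fold lower number from compound 2 to compound 4 (0.25 log units; within the scatter). Nothing shown here explains these readings.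

Still open, on these data alone, is whether any group at this carbon can move the reading beyond the scatter. A carboxylic acid or a longer chain ending in a morpholine in place of the (dimethylamino)methyl would test that.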